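The source may hold more compounds than are shown below. What is called first, only, known or untested is meant among the compounds shown, and "the series" means these compounds.

Measured so far:
Compound 1 `CN(C)c1nc2cc(Cl)c(Cl)cc2n1COC(CO)CO`: in a functional assay on KB cells (Homo sapiens) for inhibition (a lower number here means a stronger inhibitor, a higher number a weaker inhibitor), compound 1 gives > 100000 nM, a limit of the assay, not a number.
Compound 2 `Nc1nc2c(Cl)c(Cl)ccc2n1COC(CO)CO`: in this assay compound 2 gives > 100000 nM, again only a limit.
Compound 3 `CN(C)c1nc2c(Cl)c(Cl)ccc2n1COC(CO)CO`: in this assay compound 3 gives > 100000 nM, also a limit.

Compound 3 thus stands only at the limit, as do the other two values shown (the limit of > 100000 nM in this assay, at which 3 of the 3 values shown sit). Among the measured compounds shown here, the one measured step, a step that the two limits leave unreadable from compound 2 to compound 3, cannot be read, since both ends are limits. Compound 4 `OCC(CO)OCn1c(S)nc2c(Cl)c(Cl)ccc21` differs from compound 3 by sulfanyl in place of dimethylamino on an aromatic carbon. For the measured compounds named here, no measured step involves a sulfanyl group, and the single step available gives no size, so nothing in these data points to a gain beyond the scatter. Compound 4 is therefore expected to stay near the limit, with the step of a number no higher from compound 3 to compound 4 (the limit leaves the size open) expected to be small. The estimate for compound 4 in this assay is 100000 nM, between 20000 nM and 500000 nM.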

Compound 4, half-maximal inhibitory concentration: > 100000 nM
Compound 4 gave a limit, no number; the forecaster's own chance of this, stated with the estimate: 80%; the middle value lies on the limit itself.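

Compound 4 ends at a limit, as compound 2 and compound 3 do, so neither step to compound 4 can be read: the limit of > 100000 nM in this assay, at which 4 of the 4 values shown sit.

The compounds shown leave open which group on that aromatic carbon, if any, would give a readable number in this assay.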